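A Chloro Group Added to Compound 2

The source may report more compounds than this note shows. Statements on the series, on what has been measured and on what is new or still open speak of the compounds shown alone.

In an ADME assay on NIH3T3 cells (Mus musculus) for inhibition, read by CCK-8 assay, with a stated time of 48 h (on this read-out lower numbers stand for stronger inhibition and higher numbers for weaker inhibition), compound 1 (`C#CCOc1ccc(C(=O)/C=C/c2ccccc2)cc1`) gives 72900 nM and compound 2 (`C#CCOc1ccc(C(=O)/C=C/c2ccccc2)c(O)c1`) gives 66600 nM, so compound 2 stands level with compound 1 within the scatter. Compound 3 (`C#CCOc1ccc(C(=O)/C=C/c2cccc(Cl)c2)c(O)c1`) differs from compound 2 by chloro in place of hydrogen on an aromatic carbon, phenyl to 3-chlorophenyl. Among the measured compounds shown here, the only measured step, hydroxy in place of hydrogen, is a 1.1-fold lower number from compound 1 to compound 2 (0.04 log units; within the scatter) and offers no direct guide to a chloro change. The expected step in this assay is a 1.3-fold lower number from compound 2 to compound 3 (0.12 log units; within the scatter) and stays small. Compound 3 is expected at 50000 nM with 20000 nM to 110000 nM as its estimated range.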

Compound 3, half-maximal inhibitory concentration: 79500 nM
Compound 3: middle estimate off by 1.6-fold (0.20 log units), on the low side; measured number inside the range.
By their numbers in this assay, from the lowest: compounds 2, 1 and 3 (each within the scatter of the next).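

In this assay, changing phenyl to 3-chlorophenyl gives a 1.2-fold higher number from compound 2 to compound 3 (0.08 log units; within the scatter), so a chloro at this place leaves the number level with that of compound 2. Among the compounds shown here, the earlier step concerned a hydroxy in a different part of the molecule, so this is the first reading for a change on this phenyl ring. No measured information points to an explanation for this result. From the compounds shown here alone, whether a larger change here, such as an amine or a carboxylic acid in place of the chloro, would shift the number beyond the scatter remains open.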